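Replacing Pyridin-3-yl with 3-Methylphenyl: An Expected Response

The source may report more compounds than this note shows. Statements on the series, on what has been measured and on what is new or still open speak of the compounds shown alone.

Compound 1 `Cc1cc(NC(=O)Cn2nnc(-c3ccccc3)n2)n(CC2CCCCC2)n1`: in an assay on HEK293 cells for activation of Kir3.1/Kir3.2 (Homo sapiens), read by thallium flux (on this read-out lower numbers stand for smaller maximal responses and higher numbers for larger maximal responses), compound 1 gives 77%.
Compound 2 `Cc1nc(NC(=O)Cn2nnc(-c3ccccc3)n2)n(-c2ccccc2)n1`: in this assay compound 2 is reported as "not active" (no number reported).
Compound 3 `Cc1cc(NC(=O)Cn2nnc(-c3cccnc3)n2)n(C2CCCCC2)n1`: in this assay compound 3 gives 96%.

Going by the values given here, only two of the three compounds come with a number, and compound 3 stands highest of them. Compound 1 lies lower by a gap that is beyond the usual scatter, so compound 3 reaches the larger maximal response of the pair. Compound 2 gave no number at all.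

Compound 4 `Cc1cccc(-c2nnn(CC(=O)Nc3cc(C)nn3C3CCCCC3)n2)c1` differs from compound 3 in a single place: 3-methylphenyl in place of pyridin-3-yl on an aromatic carbon. Among the compounds with values here, no pair of measured compounds differs in just one place, so there is no measured step to lean on for the size of this change. Compound 1 also carries a carbon-only ring on the same five-membered aromatic ring with 4 nitrogen, but it differs from compound 3 elsewhere as well, so its lower value only hints at direction. The step of a number 11 percentage points lower from compound 3 to compound 4 (beyond the scatter) is expected to be a modest decrease, near the edge of the scatter. Compound 4 is therefore expected to give 85% in this assay, within a range from 65% to 105%.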

Compound 4, largest response reached (Emax), in percent of the reference or control that the assay uses: 93%
Beside the measured number, compound 4's estimate is 8 percentage points below it; the range from low to high includes it.
By their numbers in this assay, from the lowest: compound 1; then compounds 4 and 3 (each within the scatter of the next).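

In this assay, going by these compounds alone, putting 3-methylphenyl in place of pyridin-3-yl on an aromatic carbon of the five-membered aromatic ring with 4 nitrogen gives a number 3 percentage points lower from compound 3 to compound 4 (within the scatter), the first step here that changes only one place. The maximal responses of these two compounds cannot be told apart, so in this pair the aromatic ring at this place can lose its ring nitrogen, with its hydrogen-bond acceptor, and gain a heavy atom without a measurable change in the read-out. Nothing shown explains why the two groups read alike.

On these data alone, this single step swaps the ring nitrogen and adds the methyl together, so the effect of each alone stays open. Also open, as far as these compounds go, is whether this place would accept something other than an aromatic ring, such as a carboxylic acid, an amine or a longer chain like butyl.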